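The source may report more compounds than this note shows. Statements on the series, on what has been measured and on what is new or still open speak of the compounds shown alone.

Compound 1 `Fc1ccc(-c2cn3ccnc3c(-c3ccc4ncn(C5CCCCC5)c4c3)n2)cc1`: 2.98%
Compound 2 `CC(=O)c1ccc(-c2cn3ccnc3c(-c3ccc4ncn(C5CCCCC5)c4c3)n2)cc1`: 3.43%
Compound 3 `Clc1ccc(-c2cn3ccnc3c(-c3ccc4ncn(C5CCCCC5)c4c3)n2)cc1`: 10%

All three compounds share one core and differ only in the group on the outer benzene ring. In a functional assay on M14 cells (Homo sapiens) for inhibition, read by sulforhodamine B assay, with a stated time of 48 h, tested at 10 uM (on this read-out higher numbers stand for more inhibition at the one concentration tested (going by the name of the read-out) and lower numbers for less inhibition), compound 3 gives 10%, which is the largest of the three numbers, but the gaps a number 7 percentage points higher from compound 1 to compound 3 (within the scatter) and a number 6.6 percentage points higher from compound 2 to compound 3 (within the scatter) both lie within the scatter, so the three compounds are not separated from one another; none of them shows inhibition in this assay that can be told apart from that of the others.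

Compound 4 `Brc1ccc(-c2cn3ccnc3c(-c3ccc4ncn(C5CCCCC5)c4c3)n2)cc1` carries the same core with a single change: bromo in place of chloro on an aromatic carbon. The three measured steps all concern exactly this position, each swapping one group on that aromatic carbon for another. They read a number 0.5 percentage points higher from compound 1 to compound 2 (within the scatter), a number 7 percentage points higher from compound 1 to compound 3 (within the scatter) and a number 6.6 percentage points higher from compound 2 to compound 3 (within the scatter), and every one of them stays within the scatter. Swapping fluoro, chloro or acetyl at this place has therefore moved the read-out in this assay by nothing that can be told from repeat noise.

On that basis the step from compound 3 to compound 4 is expected to be a number 2 percentage points lower from compound 3 to compound 4 (within the scatter), that is, no change beyond the scatter. Compound 4 is estimated at 8%, with a range from 0% to 20%.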

Compound 4, a percentage reported as inhibition, at one concentration (the size of the read-out at that concentration, not a potency): 26.9%
The estimate for compound 4 lay 18.9 percentage points below the measured number, outside the stated range (above it).
By their numbers in this assay, from the lowest: compounds 1, 2 and 3 (each within the scatter of the next); then compound 4.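

In this assay, the position on the outer benzene ring, which had seemed not to respond to fluoro, acetyl or chloro, does respond to bromo, with a number 16.9 percentage points higher from compound 3 to compound 4 (beyond the scatter), a number 23.5 percentage points higher from compound 2 to compound 4 (beyond the scatter) and a number 23.9 percentage points higher from compound 1 to compound 4 (beyond the scatter). Exchanging one halogen atom for another, with no change in ring, hydrogen-bond donors, hydrogen-bond acceptors or net charge, is thus enough to produce a step beyond the scatter, and compound 4 is the only one of the four set apart from the others, although compound 4 still gives only 26.9% at the single concentration tested. Nothing measured here explains why bromo differs from chloro at this place.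

The compounds shown leave open whether this rise belongs to bromo alone or would also appear with iodo, or with a methyl, methoxy or amine group at the same place. They also leave open whether bromo would give a similar step if the shared core were changed elsewhere, and how compound 4 behaves at other concentrations.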